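Swapping thiophene for pyrrole on the enone carbonyl

The compounds below may be only part of what the source reports. "The series", "measured", "known", "first", "only" and "open" are said of these compounds alone.

Compound 1, `O=C(/C=C/c1cn(-c2ccccc2)nc1-c1cccnc1)c1cc[nH]c1`: 3300 nM
Compound 2, `O=C(/C=C/c1cn(-c2ccccc2)nc1-c1ccncc1)c1ccsc1`: 2200 nM

Of the compounds shown here, two from this series have been measured in a functional assay on Huh-7 cells (Homo sapiens) for inhibition, read by sulforhodamine B assay, with a stated time of 72 h; a higher number here means a weaker inhibitor, a lower number a stronger inhibitor. Compound 1 gives 3300 nM, and compound 2 gives 2200 nM. The two numbers lie within the usual scatter of each other, so neither compound can be called stronger than the other. Among the measured compounds shown here, compound 2 and compound 1 differ in more than one place, so no single step between them can be read off.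

Compound 3, `O=C(/C=C/c1cn(-c2ccccc2)nc1-c1ccncc1)c1cc[nH]c1`, has not been measured. It keeps the core of compound 2 and carries 1H-pyrrol-3-yl in place of thiophen-3-yl on a carbonyl carbon. The closest relative with this ketone is compound 1, whose value in this assay is 3300 nM. For the measured compounds named here, no measured pair isolates this change. The step of a 1.4-fold higher number from compound 2 to compound 3 (0.13 log units; within the scatter) is expected to stay within the scatter, perhaps a little toward weaker inhibition. Compound 3 is therefore estimated at 3000 nM, with a range from 1200 nM to 7500 nM.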

Compound 3, half-maximal inhibitory concentration: 28800 nM
The estimate for compound 3 lay 9.6-fold (0.98 log units) below the measured number; measured number above the stated range.
By their numbers in this assay, from the lowest: compounds 2 and 1 (each within the scatter of the next); then compound 3.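

In this assay, the group on the carbonyl carbon matters when the pyridin-4-yl series is held fixed: 1H-pyrrol-3-yl in place of thiophen-3-yl, both five-membered aromatic rings, gives a 13-fold higher number from compound 2 to compound 3 (1.12 log units; beyond the scatter). The pyridine attachment matters too, as pyridin-4-yl in place of pyridin-3-yl with the 1H-pyrrol-3-yl ketone kept gives an 8.7-fold higher number from compound 1 to compound 3 (0.94 log units; beyond the scatter), a dependence that the first two compounds, differing in more than one place, could not reveal. Nothing available explains either step.

The compounds shown leave open whether the hydrogen on the pyrrole nitrogen is connected to the loss, a question that a furan-3-yl or 1-methylpyrrol-3-yl group on the carbonyl carbon would address. They also leave open how the thiophen-3-yl ketone behaves with pyridin-3-yl on the shared core.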